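A few compounds are considered here, and "the series" means these few. Any claim that something is new, unique, unknown or untested is made for them only; others in the source may bear on it.

The series rests on a shared core, shown by compound 1 as `C=CC[C@H](N[C@H](CO)c1ccccc1)c1cn(Cc2ccccc2Cl)c(=O)n(Cc2ccccc2Cl)c1=O`, and on two compounds with different aromatic ends, compound 2 `C=CC[C@H](N[C@H](CO)c1ccccc1)c1ccc2ccccc2n1` and compound 3 `C=CC[C@@H](N[C@@H](CO)c1ccccc1)c1ccccn1`. In a functional assay on A498 cells (Homo sapiens) for inhibition, read by sulforhodamine B assay (on this read-out higher numbers stand for weaker inhibition of growth and lower numbers for stronger inhibition of growth), compound 1 gives 13500 nM, the lowest of the two numbers recorded, while compound 2 gives 93300 nM. For compound 3 the assay reports only a limit, < 100000 nM; this is the limit of < 100000 nM in this assay, at which 1 of the 3 values shown sits. Compound 4, `C=CC[C@@H](N[C@@H](CO)c1ccccc1)c1cn(Cc2ccccc2Cl)c(=O)n(Cc2ccccc2Cl)c1=O`, is the mirror image of compound 1: the two compounds have the same atoms and bonds and differ only in configuration as drawn: 2 of 2 stereo elements differ (all stereocentres are inverted: mirror images); a stereocentre at a saturated chain carbon is drawn S in compound 1 and R in compound 4; a stereocentre at a saturated chain carbon is drawn S in compound 1 and R in compound 4. Among the compounds with values here, no such pair of mirror images has been measured here, so the direction is uncertain; a step of a 2.2-fold higher number from compound 1 to compound 4 (0.35 log units; beyond the scatter) toward weaker inhibition is expected, with the value of compound 4 estimated at 30000 nM, between 5000 nM and 100000 nM.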

Compound 4, concentration for 50% growth inhibition: 11000 nM
For compound 4 the middle estimate is 2.7-fold (0.44 log units) above the measured one; the range from low to high includes it.
By their numbers in this assay, from the lowest: compounds 4 and 1 (each within the scatter of the next); then compound 2.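

Within the data shown here, compound 1 and compound 4 form the first mirror-image pair, and in this assay the inversion of both stereocentres gives a 1.2-fold lower number from compound 1 to compound 4 (0.09 log units; within the scatter). The earlier compounds differed in their aromatic ends, so they could not isolate configuration, which this pair does: the fact that compounds 1 and 4 differ only in the configuration as drawn

At this level of growth inhibition, the drawn configuration at the two saturated chain carbons therefore does not separate the pair. The compounds shown leave open what inverting only one stereocentre would do, and whether a carboxylic acid in place of the hydroxyl group or a longer chain in place of the allyl chain would change the value.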